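A few compounds are considered here, and "the series" means these few. Any claim that something is new, unique, unknown or untested is made for them only; others in the source may bear on it.

Compound 1 `O=C(/C=C/c1ccc2c(c1)B(O)OC2)c1ccccc1`: 6100 nM
Compound 2 `O=C(/C=C/c1ccc2c(c1)B(O)OC2)c1cccs1`: 14200 nM
Compound 3 `Cn1cccc1C(=O)/C=C/c1ccc2c(c1)B(O)OC2`: > 100000 nM

These three compounds share one core and differ only in the ring attached to the carbonyl carbon. In a functional assay on HCT-116 cells (Homo sapiens) for cytotoxicity, read by MTT assay, with a stated time of 48 h (a higher number here means a weaker inhibitor, a lower number a stronger inhibitor), compound 1 gives 6100 nM, the lowest of the two numbers given. Compound 2 sits a 2.3-fold higher number from compound 1 to compound 2 (0.37 log units; beyond the scatter), a modest weakening. For compound 3 the value is a limit of the assay, not a number (the limit of > 100000 nM in this assay, at which 1 of the 3 values shown sits); it stands an at least 16-fold higher number from compound 1 to compound 3 (1.21 log units; beyond the scatter) and an at least 7.0-fold higher number from compound 2 to compound 3 (0.84 log units; beyond the scatter).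

Compound 4 `Nc1ccc(C(=O)/C=C/c2ccc3c(c2)B(O)OC3)cc1` keeps the phenyl ring of compound 1 and adds one group to it: amino in place of hydrogen on an aromatic carbon. Among the measured compounds shown here, none of the measured steps touches a substituent on this ring; each swaps the whole ring for another, so they speak only indirectly to the change from compound 1 to compound 4. With the phenyl ring retained, a step within or close to the scatter seems more likely than a large one in either direction. Compound 4 is therefore expected to come out near 5000 nM, between 1500 nM and 20000 nM, which would mean a 1.2-fold lower number from compound 1 to compound 4 (0.09 log units; within the scatter).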

Compound 4, half-maximal inhibitory concentration: 26100 nM
Compound 4: the middle estimate sits 5.2-fold (0.72 log units) below what was measured; the whole stated range lies below it.
By their numbers in this assay, from the lowest: compound 1; then compounds 2 and 4 (each within the scatter of the next). At a limit, above all of these: compound 3.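

In this assay the step of a 4.3-fold higher number from compound 1 to compound 4 (0.63 log units; beyond the scatter) shows that the phenyl ring is sensitive to a single added group, not only to being swapped as a whole: amino, para to a large group, is enough to shift the number beyond the scatter. The step of a 1.8-fold higher number from compound 2 to compound 4 (0.26 log units; within the scatter) lies within the scatter, so the 4-aminophenyl and thiophen-2-yl rings cannot be told apart here. Compound 3 remains a limit of the assay and not a number, yet the step of an at least 3.8-fold lower number from compound 3 to compound 4 (0.58 log units; beyond the scatter) shows that compound 4 still gives a measurable value: the limit of > 100000 nM in this assay, at which 1 of the 4 values shown sits.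

Going by these compounds, whether a methoxy group or a chlorine atom in the same place on the phenyl ring would move the number as amino does remains open. So does whether an acetamide, which carries the same nitrogen on a larger group, would behave like amino.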